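Cyanoacrylate esters: whole-organism inhibition, phenyl to imidazolyl

This account rests on a few compounds, and the source may have more. Where it says the series, first, only, none or still open, it means among the compounds named here.

Two compounds of this series carry a measured value. Compound 1 `CC(C)CCOC(=O)/C(C#N)=C/c1ccc(O)c(O)c1` gives, in a functional assay on the whole organism (strain CD1) for inhibition, with Mus musculus as the target, with stated times of 15 min and 20 min, at a dose of 10 mg/kg by the subcutaneous route (a higher number here means more inhibition at the dose given (going by the name of the read-out), a lower number less inhibition), a reading of 27.2%. For the measured compounds named here, compound 2 `N#C/C(=C\c1ccccc1)C(=O)OC1CCCCC1` gives in this assay a reading of 7.1%, the lowest of the two numbers; the gap to compound 1 lies beyond the usual scatter, and as the two compounds differ in more than one place no single step is drawn between them. Compound 3 `N#C/C(=C\c1c[nH]cn1)C(=O)OC1CCCCC1` is not yet measured. Its structure differs from compound 2 in one place: 1H-imidazol-4-yl in place of phenyl on a double-bonded chain carbon bound to a double-bonded chain carbon. No measured pair in the series carries this change, so its effect cannot be read from the numbers shown. The step from compound 2 to compound 3 is expected to be small, a number 2.9 percentage points higher from compound 2 to compound 3 (within the scatter), not clearly beyond the scatter in either direction. Compound 3 is therefore estimated at 10% in this assay, with a range from 0% to 25%.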

Compound 3, a percentage reported as inhibition, in the whole organism at one dose (the size of the read-out at that dose, not a potency): 50%
Compound 3: middle estimate off by 40 percentage points, on the low side; measured number outside the range, above it.
By their numbers in this assay, from the lowest: compound 2; then compound 1; then compound 3.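

In this assay, the place on a double-bonded chain carbon bound to a double-bonded chain carbon responds strongly to the ring it carries: 1H-imidazol-4-yl in place of phenyl gives a number 42.9 percentage points higher from compound 2 to compound 3 (beyond the scatter). This single-place change shows that, with the cyclohexyl ester kept, exchanging the ring alone moves the reading well beyond the scatter, which the earlier pair, differing in more than one place, could not show. No measurement is available that accounts for the size of this step.

This one pair does not separate ring size, the ring nitrogens and the hydrogen-bond donor as contributors to the step, and a pyridyl or furyl group at this place lies outside the compounds shown. From the compounds shown here alone, whether the step carries over to a different ester, such as a longer chain, also remains open.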